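A few compounds are considered here, and "the series" means these few. Any claim that something is new, unique, unknown or untested is made for them only; others in the source may bear on it.

Compound 1 `COC(=O)CC1CCN(C[C@H]2CN(c3ccc(-n4cc(-c5ccccn5)cn4)c(F)c3)C(=O)O2)CC1` is the starting point. In an ADME assay on HEK293-A cells (Homo sapiens) for cytotoxicity, read by MTT assay, with a stated time of 48 h (on this read-out lower numbers stand for stronger inhibition and higher numbers for weaker inhibition), compound 1 gives 224 ug/mL, the lowest of the two numbers reported, though the step of a 1.4-fold higher number from compound 1 to compound 3 (0.15 log units; within the scatter) lies within the scatter, so the two cannot be ranked. Compound 3 `CS(=O)(=O)NC[C@H]1CN(c2ccc(-n3cc(-c4ccccn4)cn3)c(F)c2)C(=O)O1` gives 314 ug/mL in this assay. Compound 2 `O=C1O[C@@H](CN2CCC(O)CC2)CN1c1ccc(-n2cc(-c3ccccn3)cn2)c(F)c1` reaches only a limit of this assay, > 400 ug/mL. Because of that limit of > 400 ug/mL in this assay, at which 1 of the 3 values shown sits, the step of an at least 1.7-fold higher number from compound 1 to compound 2 (0.25 log units; that floor lies within the scatter) is a floor rather than a settled number. Compound 4 `COC(=O)NC[C@H]1CN(c2ccc(-n3cc(-c4ccccn4)cn3)c(F)c2)C(=O)O1` is not yet measured and differs from compound 1 in one place: (methoxycarbonyl)amino in place of 4-((methoxycarbonyl)methyl)piperidin-1-yl on a saturated chain carbon bound to a saturated ring carbon. The closest guide is the change to compound 3, which likewise replaced the same piperidinyl group with a small group and moved the number little. A similar shift within the scatter is therefore expected: a 1.3-fold higher number from compound 1 to compound 4 (0.11 log units; within the scatter). Compound 4 is estimated at 290 ug/mL, within 170 ug/mL to 480 ug/mL.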

Compound 4, half-maximal inhibitory concentration: 306 ug/mL
Estimate against measurement, compound 4: 1.1-fold (0.02 log units) below; the range from low to high includes it.
By their numbers in this assay, from the lowest: compounds 1, 4 and 3 (each within the scatter of the next). At a limit, above all of these: compound 2.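

Replacing the ring-bearing 4-((methoxycarbonyl)methyl)piperidin-1-yl with the smaller, ring-free (methoxycarbonyl)amino gives a 1.4-fold higher number from compound 1 to compound 4 (0.14 log units; within the scatter) in this assay, so a second small group on this saturated chain carbon also produces no readable change. With methoxycarbonyl in place of methylsulfonyl on the amine nitrogen, the step is a 1.0-fold lower number from compound 3 to compound 4 (0.01 log units; within the scatter), so these two groups cannot be told apart in this read-out. The step of an at least 1.3-fold lower number from compound 2 to compound 4 (0.11 log units; that floor lies within the scatter) is only a floor because compound 2 sits at a limit: the limit of > 400 ug/mL in this assay, at which 1 of the 4 values shown sits.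

As far as these compounds go, it remains open whether a primary amine or a carboxylic acid on this saturated chain carbon would give a step beyond the scatter.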